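The source may hold more compounds than are shown below. What is called first, only, known or untested is meant among the compounds shown, and "the series" means these compounds.

Compound 1 `O=C(NCc1cn(Cc2ccc(C(F)(F)F)cc2)nn1)c1cn(-c2ccccc2)nc1-c1ccccc1` gives 17700 nM in a functional assay on MIA PaCa-2 cells (Homo sapiens) for antiproliferative activity, read by sulforhodamine B assay, with a stated time of 48 h; a lower number here means a stronger inhibitor of growth, a higher number a weaker inhibitor of growth. Compound 2 `COc1cc(Cn2cc(CNC(=O)c3cn(-c4ccccc4)nc3-c3ccccc3)nn2)cc(OC)c1` gives 190 nM, the lowest of the two numbers, after a 93-fold lower number from compound 1 to compound 2 (1.97 log units; beyond the scatter). Compound 3 `COc1cc(Cn2cc(CNC(=O)c3cn(-c4ccccc4)nc3-c3ccccc3)nn2)cc(OC)c1OC` carries methoxy in place of hydrogen on an aromatic carbon. For the measured compounds named here, no measured step touches this position; the one step seen swaps the whole aryl group and was large, so it does not set the size here. A small step in this assay, toward a lower number or none beyond the scatter, is expected for compound 3, that is a 1.7-fold lower number from compound 2 to compound 3 (0.24 log units; within the scatter). Compound 3 is estimated at 110 nM, within 30 nM to 500 nM.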

Compound 3, concentration for 50% growth inhibition: 1000 nM
Compound 3: the middle estimate sits 9.1-fold (0.96 log units) below what was measured; measured number above the stated range.
By their numbers in this assay, from the lowest: compound 2; then compound 3; then compound 1.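

On the aromatic carbon para to a large group, methoxy is not a silent addition in this assay: a 5.3-fold higher number from compound 2 to compound 3 (0.72 log units; beyond the scatter) marks a loss on going from 3,5-dimethoxyphenyl to 3,4,5-trimethoxyphenyl. The 3,4,5-trimethoxyphenyl group still keeps a clear gain over 4-(trifluoromethyl)phenyl, with an 18-fold lower number from compound 1 to compound 3 (1.25 log units; beyond the scatter) in this comparison. Nothing at hand accounts for the loss on adding methoxy.

From the compounds shown here alone, it stays open whether the loss belongs to methoxy itself or to any group on this carbon. A hydroxy group or an amine there would test this.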